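This account rests on a few compounds, and the source may have more. Where it says the series, first, only, none or still open, it means among the compounds named here.

Measured compounds:
Compound 1 `NC(=O)COc1cc(=O)oc2cc(OCc3cccc(Cl)c3)ccc12` — 3.1 nM; 3.31 nM (2 entries)
Compound 2 `CN(C)C(=O)COc1cc(=O)oc2cc(OCc3cccc(Cl)c3)ccc12` — 501 nM
Compound 3 `CCOC(=O)Nc1cc(=O)oc2cc(OCc3cccc(Cl)c3)ccc12` — 589 nM

In an assay on isolated protein (strain Sprague-Dawley) for inhibition of Amine oxidase [flavin-containing] B (Rattus norvegicus), read by spectrophotometry, with a stated time of 5 min (a higher number here means a weaker inhibitor, a lower number a stronger inhibitor), compound 3 gives the highest of the two single numbers, and the step of a 1.2-fold higher number from compound 2 to compound 3 (0.07 log units; within the scatter) lies within the scatter. Compound 1 is known from repeated entries (the several entries of compound 1 in this assay, 3.1 nM; 3.31 nM (2 entries)).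

Compound 4 `CC(=O)c1cc(=O)oc2cc(OCc3cccc(Cl)c3)ccc12` carries the change (acetyl in place of (ethoxycarbonyl)amino on an aromatic carbon). Within the data shown here, no measured step swaps this pair of groups; the one comparable step, from compound 2 to compound 3, was small and exchanged different groups, so it gives only weak guidance. The step of a 2.0-fold lower number from compound 3 to compound 4 (0.29 log units; within the scatter) is therefore expected to stay close to the scatter, with a wide range. Compound 4 is estimated at 300 nM, between 50 nM and 2000 nM.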

Compound 4, half-maximal inhibitory concentration: 39.8 nM
Compound 4: middle estimate off by 7.5-fold (0.88 log units), on the high side; measured number outside the range, below it.
By their numbers in this assay, from the lowest: compound 4; then compounds 2 and 3 (each within the scatter of the next).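

The group on this aromatic carbon, opposite the ring oxygen, can strongly change the result: a 15-fold lower number from compound 3 to compound 4 (1.17 log units; beyond the scatter) and a 13-fold lower number from compound 2 to compound 4 (1.10 log units; beyond the scatter) both lie beyond the scatter, whereas a 1.2-fold higher number from compound 2 to compound 3 (0.07 log units; within the scatter) stayed within it. The entering acetyl is smaller than (ethoxycarbonyl)amino and has no hydrogen-bond donor, but nothing measured here shows which difference matters, or why.

The number for compound 4 remains higher than that for compound 1, at 3.1 nM; 3.31 nM (2 entries). On these data alone, whether a longer ketone chain, an amine or a carboxylic acid here would keep a low number remains open.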